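The source may hold more compounds than are shown below. What is called first, only, known or untested is meant among the compounds shown, and "the series" means these compounds.

Measured in a functional assay on HCT-116 cells (Homo sapiens) for cytotoxicity, read by sulforhodamine B assay, with a stated time of 48 h; a higher number here means a weaker inhibitor, a lower number a stronger inhibitor:
compound 1 `O=C(Nc1n[nH]c2c1CN(C(=O)c1ccccc1)C2)c1ccc(F)cc1`: 3190 nM
compound 2 `CCC(=O)n1nc(NC(=O)c2ccccc2)c2c1CN(C(=O)c1ccccc1)C2`: 1060 nM
compound 3 `O=C(Nc1nn(C(=O)c2ccccc2)c2c1CN(C(=O)c1ccccc1)C2)c1ccccc1`: 1400 nM

Compound 3 at 1400 nM lies within the scatter of compound 2 at 1060 nM. Compound 1 at 3190 nM gives a higher number than compound 3, a gap beyond the scatter.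

Compound 4 `O=C(Nc1nn(C(=O)c2ccccc2)c2c1CN(C(=O)c1ccccc1)C2)c1ccc(F)cc1` has fluoro in place of hydrogen on an aromatic carbon, turning the benzamido group of compound 3 into ((4-fluorophenyl)carbonyl)amino: fluoro in place of hydrogen on an aromatic carbon.

Going by the values given here, the only measured step, a 1.3-fold higher number from compound 2 to compound 3 (0.12 log units; within the scatter), is phenyl in place of ethyl on a carbonyl carbon, a different change at a different site. It bears on this change only indirectly, as a sign of how little the number moved in this assay. Compound 1 also carries the 4-fluorophenyl group, but no measured partner isolates the fluoro. No shift in either direction beyond the scatter is therefore expected. The estimated step is a 1.1-fold lower number from compound 3 to compound 4 (0.03 log units; within the scatter), which is expected to stay within the scatter. For compound 4 the estimate is 1300 nM, with an expected range from 600 nM to 3000 nM.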

Compound 4, half-maximal inhibitory concentration: 2780 nM
Estimate against measurement, compound 4: 2.1-fold (0.33 log units) below, and the stated range covers the measured number.
By their numbers in this assay, from the lowest: compounds 2, 3, 4 and 1 (each within the scatter of the next, the first and the last beyond it).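

With compound 4, the 4-fluorophenyl group gets its first matched reading in this assay: a 2.0-fold higher number from compound 3 to compound 4 (0.30 log units; within the scatter), so fluoro in place of hydrogen on this aromatic carbon does not move the number beyond the scatter. Going by these compounds alone, the same compound also gives the first matched reading of the aromatic nitrogen with the 4-fluorophenyl group in place: benzoyl in place of hydrogen there gives a 1.1-fold lower number from compound 1 to compound 4 (0.06 log units; within the scatter), so neither single change separates its pair in this assay. Nothing measured here accounts for either step.

From the compounds shown here alone, whether a methoxy, an amine or a carboxylic acid in place of the fluoro would give a step beyond the scatter remains open. So does the effect of a longer chain on the carbonyl carbon at the aromatic nitrogen, where only ethyl and phenyl appear.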